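The source may hold more compounds than are shown below. What is called first, only, known or untested is meant among the compounds shown, and "the series" means these compounds.

Measured so far in a functional assay (Homo sapiens) for inhibition; on this read-out lower numbers stand for stronger inhibition and higher numbers for weaker inhibition
- compound 1 `CCCCOc1ccc(C(=O)/C=C/c2c(OC)cccc2OC)cc1` gives 127000 nM
- compound 2 `C=CCOc1ccc(C(=O)/C=C/c2c(OC)cccc2OC)cc1` gives 96000 nM
- compound 3 `COc1cccc(OC)c1/C=C/C(=O)c1ccc(O)cc1` gives 60000 nM

Compound 3 stands clear of compound 1, with a 2.1-fold lower number from compound 1 to compound 3 (0.33 log units; beyond the scatter) as a modest step, but level with compound 2, with a 1.6-fold lower number from compound 2 to compound 3 (0.20 log units; within the scatter) as the step between them. Next is compound 4 `COc1cc(OC)c(/C=C/C(=O)c2ccc(O)cc2)c(OC)c1`, which differs from compound 3 by methoxy in place of hydrogen on an aromatic carbon as its single change. Among the compounds with values here, no measured step touches such a carbon. Within the data shown here, the steps of a 1.3-fold lower number from compound 1 to compound 2 (0.12 log units; within the scatter) and the two above all change a group on an oxygen on an aromatic ring, so they bear on this change only indirectly, and the data offer no direct precedent. They do show small movement across these three compounds, so no step beyond the scatter is expected in this assay, and no direction is favoured. The expected step is a 1.1-fold lower number from compound 3 to compound 4 (0.04 log units; within the scatter) as a working estimate. For compound 4 the estimated value is 55000 nM with an expected range from 22000 nM to 130000 nM as its bounds.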

Compound 4, half-maximal inhibitory concentration: 44000 nM
For compound 4 the middle estimate is 1.3-fold (0.10 log units) above the measured one, and the stated range covers the measured number.
By their numbers in this assay, from the lowest: compounds 4, 3, 2 and 1 (each within the scatter of the next, the first and the last beyond it).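

Methoxy in place of hydrogen on an aromatic carbon, para to a large group and meta to two methoxy groups, gives in this assay a 1.4-fold lower number from compound 3 to compound 4 (0.13 log units; within the scatter) and so leaves compound 4 level with compound 3. Within the data shown here, this is the first reading of a change on this aromatic carbon, since the earlier steps all concerned the group on an oxygen on the other aromatic ring, and it shows that this position accepts a methoxy group with no shift beyond the scatter. No supporting data bear on why the read-out holds here.

Open, going by these compounds, is whether a different group on this carbon, such as an amine, a carboxylic acid or a longer chain like butoxy, would also stay within the scatter. Also open, on these data alone, is whether this methoxy group behaves the same alongside butyl or allyl on the oxygen.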